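Straightening a branched side chain in a low-toxicity series

The source may hold more compounds than are shown below. What is called first, only, known or untested is meant among the compounds shown, and "the series" means these compounds.

Compound 1, `Nc1nc(NCc2ccccc2)c2ncn(/C=C3/CC3(CO)CO)c2n1`: > 24000 nM
Compound 2, `CC(C)CNc1nc(N)nc2c1ncn2/C=C1/CC1(CO)CO`: > 24000 nM

In an ADME assay on Akata cells (Homo sapiens) for cytotoxicity, with a stated time of 7 days (on this read-out higher numbers stand for lower toxicity in this test and lower numbers for higher toxicity in this test), compound 1 gives only a limit of the assay, > 24000 nM. Compound 2 also gives only a limit in this assay, > 24000 nM. For the measured compounds named here, the one measured step, a step that the two limits leave unreadable from compound 1 to compound 2, therefore cannot be read, since (the limit of > 24000 nM in this assay, at which 2 of the 2 values shown sit).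

Compound 3, `CCCCNc1nc(N)nc2c1ncn2/C=C1/CC1(CO)CO`, has not been measured yet. It differs from compound 2 in one place: propyl in place of isopropyl on a saturated chain carbon bound to a nitrogen on an aromatic ring. Going by the values given here, the only step bearing on this change is a step that the two limits leave unreadable from compound 1 to compound 2, which is unreadable, so the data give no direction. Both measured compounds sit at the same limit, and the expectation is that the step that the limit leaves unreadable from compound 2 to compound 3 will be none beyond the usual scatter. Compound 3 is therefore expected to give 40000 nM, with a range from 24000 nM to 100000 nM, most likely again reported only as a limit.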

Compound 3, half-maximal cytotoxic concentration: > 24000 nM
Compound 3 ended at the assay's limit; the forecaster's own chance of this, stated with the estimate: 85%; the middle value lies beyond the limit too.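

Compound 3 also gives only a limit, so no step among compound 1, compound 2 and compound 3 can be read, for this reason: the limit of > 24000 nM in this assay, at which 3 of the 3 values shown sit.

What the compounds shown leave open is how toxic any of them actually is, and whether the side chain on the nitrogen matters at all in this assay.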